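Methoxyphenyl swap on the series: compound 3 to compound 4

A few compounds are considered here, and "the series" means these few. Any claim that something is new, unique, unknown or untested is made for them only; others in the source may bear on it.

Measured so far in an ADME assay on MT4 cells (Homo sapiens) for cytotoxicity, read by MTT assay, with a stated time of 5 days; a lower number here means that less compound is tolerated, a higher number that more compound is tolerated
compound 1 `N#Cc1ccc(Nc2nccc(OCc3ccc(Cl)cc3)n2)cc1` gives 156000 nM
compound 2 `N#Cc1ccc(Nc2nccc(OCc3cccc(Br)c3)n2)cc1` gives 221000 nM
compound 3 `COc1ccccc1COc1ccnc(Nc2ccc(C#N)cc2)n1` gives 8900 nM

Compound 3 has the lowest number of the three in this assay, and its steps to both others lie beyond the scatter. The next compound is compound 4 `COc1ccc(COc2ccnc(Nc3ccc(C#N)cc3)n2)cc1`, with the change 4-methoxyphenyl in place of 2-methoxyphenyl on a saturated chain carbon bound to an oxygen on an aromatic ring.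

Among the measured compounds shown here, two measured steps bear on this most directly: an 18-fold lower number from compound 1 to compound 3 (1.24 log units; beyond the scatter) and a 25-fold lower number from compound 2 to compound 3 (1.40 log units; beyond the scatter). Both lead to the 2-methoxyphenyl group. The remaining step, a 1.4-fold higher number from compound 1 to compound 2 (0.15 log units; within the scatter), shows 4-chlorophenyl and 3-bromophenyl as alike within the scatter. For the measured compounds named here, no measured compound carries 4-methoxyphenyl, so the direct evidence is thin. A rise in this assay is expected, probably covering part of the distance back towards compound 1 at 156000 nM. The expected step is a 6.7-fold higher number from compound 3 to compound 4 (0.83 log units; beyond the scatter). For compound 4 the estimated value is 60000 nM, with an expected range from 12000 nM to 250000 nM.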

Compound 4, half-maximal cytotoxic concentration: 102000 nM
Estimate against measurement, compound 4: 1.7-fold (0.23 log units) below; measured number inside the range.
By their numbers in this assay, from the lowest: compound 3; then compounds 4, 1 and 2 (each within the scatter of the next, the first and the last beyond it).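

In this assay the shift to 4-methoxyphenyl from 2-methoxyphenyl brings an 11-fold higher number from compound 3 to compound 4 (1.06 log units; beyond the scatter) and so ties the low number of compound 3 to 2-methoxyphenyl, not to methoxy as such. Methoxy in place of chloro on an aromatic carbon gives a 1.5-fold lower number from compound 1 to compound 4 (0.18 log units; within the scatter) and leaves the two alike, while 4-methoxyphenyl in place of 3-bromophenyl gives a 2.2-fold lower number from compound 2 to compound 4 (0.34 log units; beyond the scatter) as a modest gap only. No measurement here speaks to why 2-methoxyphenyl stands apart.

Open, from the compounds shown here alone, is whether 3-methoxyphenyl tracks 4-methoxyphenyl or 2-methoxyphenyl. Also open, going by these compounds, is whether the low number is peculiar to 2-methoxyphenyl or returns with 2-chlorophenyl, 2-ethoxyphenyl or 2-hydroxyphenyl on the same saturated chain carbon.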